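From compound 1 to compound 4: a step behind limits

A few compounds are considered here, and "the series" means these few. Any claim that something is new, unique, unknown or untested is made for them only; others in the source may bear on it.

Compound 1 `C=CC(=O)N1CCN(S(=O)(=O)c2ccc(NC(=O)OCc3ccccc3)cc2)CC1`: > 6 h (a limit)
Compound 2 `C=CC(=O)N[C@H]1CCCN(S(=O)(=O)c2ccc(NC(=O)OCc3ccccc3)cc2)C1`: > 6 h (a limit)
Compound 3 `C=CC(=O)N[C@@H]1CCCN(S(=O)(=O)c2ccc(NC(=O)OCc3ccccc3)cc2)C1`: > 6 h (a limit)

In an ADME assay on a cell-free system (plasma, Homo sapiens) for metabolic stability, tested at 1 uM (a higher number here means that the compound lasts longer, a lower number that the compound disappears faster), compound 1 stands at > 6 h, which is a limit of the assay and not a number. Compound 4 `C=CC(=O)NC1CN(S(=O)(=O)c2ccc(NC(=O)OCc3ccccc3)cc2)C1` carries one change, on a sulfonyl sulfur: a group of 9 heavy atoms (6 carbon, 2 nitrogen, 1 oxygen; one four-membered non-aromatic ring with 1 hetero atom) in place of a group of 10 heavy atoms (7 carbon, 2 nitrogen, 1 oxygen; one six-membered non-aromatic ring with 2 hetero atoms), on a sulfonyl sulfur. The data hold one feature in common, (the limit of > 6 h in this assay, at which 3 of the 3 values shown sit). Going by the values given here, the only measured step, a step that the two limits leave unreadable from compound 2 to compound 3, offers no size to carry over, and it concerns a different kind of change, (the fact that compounds 2 and 3 differ only in the configuration as drawn). No shift beyond the scatter, in either direction, is therefore expected in this assay. The estimated step is a step that the limit leaves unreadable from compound 1 to compound 4. Compound 4 is expected at 8 h, within an estimated range of 5 h to 20 h.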

Compound 4, half-life: > 6 h
Compound 4 gave a limit, no number; the forecaster's own chance of this, stated with the estimate: 85%; the middle value lies beyond the limit too.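

No size can be read for the step between compound 1 and compound 4, since both values are limits and not numbers: the limit of > 6 h in this assay, at which 4 of the 4 values shown sit.

The compounds shown leave open how long each one truly lasts in this assay, and so whether the change on the sulfonyl sulfur makes any difference.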